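The compounds below may be only part of what the source reports. "The series", "measured", "known", "first", "only" and "open" are said of these compounds alone.

Compound 1 `N#CC1=C(N)Oc2c(c3nc4ccccc4nc3c3ccccc23)C12C(=O)N(Cc1cnnn1-c1cc(Cl)ccc1Cl)c1ccccc12` and compound 2 `N#CC1=C(N)Oc2c(N)cc3nc4ccccc4nc3c2C12C(=O)N(Cc1cnnn1-c1ccccc1Br)c1ccccc12` share one core and differ in the group on the aromatic nitrogen. In a functional assay on MCF7 cells (Homo sapiens) for antiproliferative activity, read by MTT assay, with a stated time of 48 h (on this read-out higher numbers stand for weaker inhibition and lower numbers for stronger inhibition), compound 1 reaches only the limit of the assay, > 50000 nM. For the measured compounds named here, compound 2 gives 30700 nM in this assay, which is the only plain number among the two values shown. Compound 3 `N#CC1=C(N)Oc2c(N)cc3nc4ccccc4nc3c2C12C(=O)N(Cc1cnnn1-c1ccc(F)c(Cl)c1)c1ccccc12` differs from compound 2 by 3-chloro-4-fluorophenyl in place of 2-bromophenyl on an aromatic nitrogen. Going by the values given here, no measured step of this kind is available, so in this assay nothing beyond the usual scatter is expected. Compound 3 is expected to give about 35000 nM, within 12000 nM to 100000 nM. The expected step is a 1.1-fold higher number from compound 2 to compound 3 (0.06 log units; within the scatter).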

Compound 3, half-maximal inhibitory concentration: 17800 nM
Compound 3: middle estimate off by 2.0-fold (0.29 log units), on the high side; the measured number falls inside the stated range.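

On this aromatic nitrogen, 3-chloro-4-fluorophenyl in place of 2-bromophenyl gives a 1.7-fold lower number from compound 2 to compound 3 (0.24 log units; within the scatter) in this assay. For the compounds shown here, this is the first step at this position that can be read between two plain numbers, and it does not tell these two halogen-bearing phenyl groups apart. Both numbers also lie in a range that ends at a limit: the limit of > 50000 nM in this assay, at which 1 of the 3 values shown sits.

On these data alone, whether any group here can move the number beyond the scatter stays open. So does whether a phenyl ring is needed at all, which an amine, a carboxylic acid or a longer alkyl chain in its place would test.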